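The source may report more compounds than this note shows. Statements on the series, on what has been measured and on what is new or still open speak of the compounds shown alone.

Working notes on the series. Two compounds have numbers in a functional assay on CHO-K1 cells for agonist activity at Glucose-dependent insulinotropic receptor (Homo sapiens), read by a luciferase reporter, with a stated time of 5 h; on this read-out lower numbers stand for an effect already at smaller amounts and higher numbers for an effect only at larger amounts of compound. Compound 1 `CC(C)OC(=O)N1CCC(Oc2cccc3c2CCN3c2ccc(S(C)(=O)=O)cc2F)CC1` gives 1000 nM there. Compound 2 `CC(C)OC(=O)N1CCC(Oc2ncnc3c2CCN3c2ccc(S(C)(=O)=O)cn2)CC1` gives 126 nM in this assay, the lowest of the two numbers; the gap to compound 1 lies beyond the scatter, but the two structures differ in more than one place, so no single step can be read from them.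

Compound 3 `CC(C)OC(=O)N1CCC(Oc2ncnc3c2CCN3c2ccc([S@@+](C)[O-])c(F)c2)CC1` keeps the core of compound 2 and changes the group on the ring nitrogen: a group of 10 heavy atoms (7 carbon, 1 oxygen, 1 fluorine, 1 sulfur; one six-membered aromatic ring of carbon only) in place of a group of 10 heavy atoms (6 carbon, 1 nitrogen, 2 oxygen, 1 sulfur; one six-membered aromatic ring with 1 hetero atom), on a nitrogen on an aromatic ring in a ring. Among the compounds with values here, no measured pair isolates this change, so the direction must be estimated. The entering group shares its fluorine and its six-membered aromatic ring of carbon only with compound 1, and the loss of two hydrogen-bond acceptors is taken to count against compound 3. The estimated step is a 2.8-fold higher number from compound 2 to compound 3 (0.44 log units; beyond the scatter), a rise beyond the scatter. Compound 3 is expected to give 350 nM, within 90 nM to 1500 nM.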

Compound 3, half-maximal effective concentration: 631 nM
For compound 3 the middle estimate is 1.8-fold (0.26 log units) below the measured one; the range from low to high includes it.
By their numbers in this assay, from the lowest: compound 2; then compounds 3 and 1 (each within the scatter of the next).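

The place on a nitrogen on an aromatic ring in a ring now has its first single-place reading: in this assay the change of group gives a 5.0-fold higher number from compound 2 to compound 3 (0.70 log units; beyond the scatter) and so the series responds to this position. The 5-(methylsulfonyl)pyridin-2-yl group of compound 2 is the better of the two groups tried here. The step bundles several differences at once: the ring hetero atom, the fluorine, the sulfur group with its defined stereocentre, and the fall in hydrogen-bond acceptors, and nothing available explains the step.

Which of these differences carries the step stays open, as does the effect of the opposite configuration at that stereocentre. Also open, going by these compounds, is how this position would respond to a ring carrying a nitrile, an amine or a carboxylic acid in place of the sulfur group.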